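This account rests on a few compounds, and the source may have more. Where it says the series, first, only, none or still open, it means among the compounds named here.

Compound 1 `COc1cc2c(cc1OC)C(=O)C(CC1CCN(C(=S)Nc3ccccc3C)CC1)C2` was tested in a functional assay on the whole organism (strain Swiss albino) with Mus musculus as the target, with a stated time of 0.5 h (on this read-out higher numbers stand for an effect only at larger amounts of compound and lower numbers for an effect already at smaller amounts), and in this assay compound 1 gives 300 mg/kg. Compound 2 `COc1cc2c(cc1OC)C(=O)C(CC1CCN(C(=S)Nc3cccc(Cl)c3)CC1)C2` shares the whole core and differs only in the group on the thiourea nitrogen, yet for compound 2 this assay reports "not determined" (no result reported), so compound 2 has no number to stand on. Compound 3 `CCCCNC(=S)N1CCC(CC2Cc3cc(OC)c(OC)cc3C2=O)CC1` follows from compound 2 by the change (butyl in place of 3-chlorophenyl on an amide-type nitrogen). With compound 2 unmeasured, no step can be read, and only a rough expectation remains, resting on compound 1 because compound 1 gives 300 mg/kg. Compound 3 is therefore expected to give about 300 mg/kg, within 100 mg/kg to 1000 mg/kg.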

Compound 3, minimum effective dose: 100 mg/kg
Compound 3: middle estimate off by 3.0-fold (0.48 log units), on the high side; the range from low to high includes it.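

In this assay the aromatic ring on the amide-type nitrogen can give way to an open chain without loss: butyl in place of 2-methylphenyl gives a 3.0-fold lower number from compound 1 to compound 3 (0.48 log units; beyond the scatter) and so moves the effect to a smaller dose. The step from compound 2 cannot be read, and nothing available explains the shift. From the compounds shown here alone, whether a longer chain, such as hexyl, would lower the dose further stays open. So does the effect of a butyl chain ending in an amine or a carboxylic acid.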